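Swapping Methylsulfanyl for Ethyl on a Fused Core

The source may report more compounds than this note shows. Statements on the series, on what has been measured and on what is new or still open speak of the compounds shown alone.

Of the compounds shown here, three have been measured in a functional assay on the whole organism (Pleural cavity) for inhibition, with Rattus norvegicus as the target, at a dose of 25 mg/kg; on this read-out higher numbers stand for more inhibition at the one dose given (going by the name of the read-out) and lower numbers for less inhibition. Compound 1 `CC1(C)C(=O)N(c2ccccc2Cl)c2ncccc21` gives 14%, compound 2 `CC1(C)C(=O)N(c2ccc(S(C)(=O)=O)cc2)c2ncccc21` gives 42%, and compound 3 `CSC1(C)C(=O)N(c2ccccc2)c2ncccc21` gives 34%. Compound 3 thus stands second highest of the three: its number lies within the usual scatter of that of compound 2, and beyond the scatter above that of compound 1. Compound 4 `CCC1(C)C(=O)N(c2ccccc2)c2ncccc21` has not yet been measured. It differs from compound 3 in one place: ethyl in place of methylsulfanyl on a saturated ring carbon. Among the measured compounds shown here, no measured pair shows this kind of change, so nothing here tells how large its effect is. A small step, within the scatter and in either direction, is expected: a number 4 percentage points lower from compound 3 to compound 4 (within the scatter). Compound 4 is therefore estimated at 30%, between 12% and 48%.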

Compound 4, a percentage reported as inhibition, in the whole organism at one dose (the size of the read-out at that dose, not a potency): 36%
Beside the measured number, compound 4's estimate is 6 percentage points below it; low and high end bracket the measured number.
By their numbers in this assay, from the lowest: compound 1; then compounds 3, 4 and 2 (each within the scatter of the next).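

Ethyl in place of methylsulfanyl on this saturated ring carbon gives a number 2 percentage points higher from compound 3 to compound 4 (within the scatter) in this assay. For this one pair, the sulfur of methylsulfanyl is therefore not needed to keep the inhibition at this level, and the position accepts an all-carbon group with no change beyond the scatter. No measurement here offers an explanation for this result.

From the compounds shown here alone, whether a longer chain such as propyl, an amine or a carboxylic acid on this carbon would shift the number beyond the scatter remains open. So does whether the same swap would behave alike in compounds with a different group on the ring nitrogen.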